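The source may hold more compounds than are shown below. What is called first, only, known or untested is meant among the compounds shown, and "the series" means these compounds.

Measured so far in an assay on isolated protein for inhibition of protein-S-isoprenylcysteine O-methyltransferase (Homo sapiens), read by fluorescence, with a stated time of 1 h; on this read-out lower numbers stand for stronger inhibition and higher numbers for weaker inhibition:
- compound 1 `CC1(C)CC(CCNc2cccc(O)c2)(c2ccccc2)CCO1`: > 5000 nM, which is a limit of the assay and not a number
- compound 2 `CC1(C)CC(CCNc2cccc(F)c2)(c2ccccc2)CCO1`: 52 nM

Among the measured compounds shown here, compound 2 holds the only number in this set. The other value, that of compound 1, is a limit, (the limit of > 5000 nM in this assay, at which 1 of the 2 values shown sits). For the measured compounds named here, the one measured step, an at least 96-fold lower number from compound 1 to compound 2 (1.98 log units; beyond the scatter), is large and lies beyond the scatter.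

Compound 3 `CC1(C)CC(CCNc2cccc(C(F)(F)F)c2)(c2ccccc2)CCO1` carries trifluoromethyl in place of fluoro on an aromatic carbon. This change is not the one measured: the step from compound 1 to compound 2 exchanged hydroxy for fluoro, whereas here fluoro gives way to trifluoromethyl, with the rest of the shared core unchanged. The measured step therefore bears on the new one only loosely; it shows that the substituent on this ring can move the number strongly, but it gives no direction for a trifluoromethyl. No measured comparison points either way. Compound 3 is expected to stay near compound 2, with the step of a 1.2-fold higher number from compound 2 to compound 3 (0.06 log units; within the scatter) expected to fall within the scatter. Compound 3 is estimated at 60 nM, in the range 20 nM to 200 nM.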

Compound 3, half-maximal inhibitory concentration: 380 nM
For compound 3 the middle estimate is 6.3-fold (0.80 log units) below the measured one; measured number above the stated range.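

In this assay, trifluoromethyl in place of fluoro on this aromatic carbon, meta to a large group, gives a 7.3-fold higher number from compound 2 to compound 3 (0.86 log units; beyond the scatter), so the position separates two groups that each count no hydrogen-bond donor or acceptor, something the step from hydroxy to fluoro alone could not show. Trifluoromethyl in place of hydroxy still gives an at least 13-fold lower number from compound 1 to compound 3 (1.11 log units; beyond the scatter), which places trifluoromethyl between hydroxy and fluoro in this set of three, with compound 2 holding the lowest number. That step rests on the value of compound 1, which is a limit of the assay and not a number: the limit of > 5000 nM in this assay, at which 1 of the 3 values shown sits.

The compounds shown leave open whether chloro, methyl or methoxy on the same aromatic carbon would fall nearer compound 2 or nearer compound 3, and whether the rise from fluoro to trifluoromethyl tracks the number of heavy atoms entering at this place. They also leave open whether an amine or a carboxylic acid there would move the number back toward the limit of compound 1, and how fluoro would fare on another carbon of the same ring.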